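A few compounds are considered here, and "the series" means these few. Any claim that something is new, unique, unknown or untested is made for them only; others in the source may bear on it.

Measured in a functional assay on SW480 cells (Homo sapiens) for antiproliferative activity, read by MTT assay, with a stated time of 48 h; a higher number here means a weaker inhibitor, a lower number a stronger inhibitor:
- compound 1 `CCCCCC(CCO)n1c(Br)nc2c(Cl)ncnc21`: 23800 nM
- compound 2 `CCCCCCCC(CCO)n1c(Br)nc2c(Cl)ncnc21`: 14400 nM

Compound 2 stands at 14400 nM, within the scatter of compound 1, so this pair gives no ranking. Within the data shown here, only these two numbers are available for the series so far.

Compound 3 `CCCCCCCCC(CCO)n1c(Br)nc2c(Cl)ncnc21` comes from compound 2 by a single change: methyl in place of hydrogen on a saturated chain carbon, eight bonds along the chain from an aromatic nitrogen. Cut one bond further out, the same difference reads propyl to butyl.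

Among the measured compounds shown here, the one measured step that bears on this change is the earlier lengthening of the same chain, with ethyl in place of hydrogen: a 1.7-fold lower number from compound 1 to compound 2 (0.22 log units; within the scatter). That step did not leave the scatter, and the present change enters only a methyl. With this single step as the guide, no step beyond the scatter is expected in this assay, and any drift is expected to be slight and towards a lower number.

The estimated step is a 1.2-fold lower number from compound 2 to compound 3 (0.08 log units; within the scatter). For compound 3 the expected value is 12000 nM, with an estimated range of 6000 nM to 24000 nM.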

Compound 3, half-maximal inhibitory concentration: 17800 nM
Compound 3: middle estimate off by 1.5-fold (0.17 log units), on the low side; the measured number falls inside the stated range.
By their numbers in this assay, from the lowest: compounds 2, 3 and 1 (each within the scatter of the next).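

In this assay, methyl in place of hydrogen on a saturated chain carbon, eight bonds along the chain from an aromatic nitrogen, gives a step that stays inside the scatter (a 1.2-fold higher number from compound 2 to compound 3 (0.09 log units; within the scatter)), so this further extension of the chain, read as propyl to butyl when cut one bond further out, separates compound 3 from compound 2 by no meaningful margin. The longer span of the same chain also stays inside the scatter (a 1.3-fold lower number from compound 1 to compound 3 (0.13 log units; within the scatter)), so compound 1, compound 2 and compound 3 show no ranking and no trend with chain length. No supporting measurement bears on this result.

Still open, on these data alone, is whether a substantially longer chain, or one ending in an amine or a carboxylic acid, would give a step beyond the scatter. Also open, as far as these compounds go, is whether a branched chain or a phenyl ring at this chain end would separate from these three compounds in this assay.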